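This account rests on a few compounds, and the source may have more. Where it says the series, first, only, none or still open, it means among the compounds named here.

In an ADME assay on Vero cells (Chlorocebus sabaeus) for cytotoxicity, read by MTT assay, with a stated time of 24 h (a higher number here means a weaker inhibitor, a lower number a stronger inhibitor), the starting point is compound 3 `O=C1c2ccccc2OCC1Cc1ccc(O)cc1`. Compound 3 gives > 200000 nM, which is a limit of the assay and not a number. Compound 1 `Cc1ccc2c(c1)OCC(Cc1ccc(O)cc1)C2=O` gives > 200000 nM, again a limit. Compound 2 `O=C1c2ccccc2OCC1Cc1ccc(F)cc1` gives > 200000 nM, also a limit. What these three compounds share is the limit of > 200000 nM in this assay, at which 3 of the 3 values shown sit.

Compound 4 `Cc1ccc(CC2COc3ccccc3C2=O)cc1` has not yet been measured. It differs from compound 3 by a single swap, methyl in place of hydroxy on an aromatic carbon, para to a large group.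

Among the compounds with values here, two measured steps bear on this swap. Within the data shown here, the first is a step that the two limits leave unreadable from compound 2 to compound 3, with hydroxy in place of fluoro on an aromatic carbon. The second is a step that the two limits leave unreadable from compound 1 to compound 3, with hydrogen in place of methyl on an aromatic carbon. Neither has a size that can be read, so neither offers a number to carry over to the new swap. All that remains is the shared limit of the three measured compounds, and it points in no direction. No step beyond the usual scatter is therefore expected, and the assay may well report only a limit again. The expected step is a number no higher from compound 3 to compound 4 (the limit leaves the size open). For compound 4 the estimate is 200000 nM, with an expected range from 100000 nM to 400000 nM.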

Compound 4, half-maximal inhibitory concentration: > 200000 nM
Compound 4: a limit, no number; the forecaster's own chance of this, stated with the estimate: 85%; the middle value sits exactly at the limit.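

In this assay compound 4 gives > 200000 nM, a limit of the assay and not a number. The steps to compound 4 from compound 3 and from compound 2 cannot be read. The compounds shown leave open whether any of these swaps changes the read-out at all, with every compound resting on the same mark: the limit of > 200000 nM in this assay, at which 4 of the 4 values shown sit.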